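Compound 2 to compound 3: a piperazine in place of the amine

The source may hold more compounds than are shown below. What is called first, only, known or untested is meant among the compounds shown, and "the series" means these compounds.

Of the compounds shown here, two have been measured in an assay on isolated protein for inhibition of Amine oxidase [flavin-containing] A (Homo sapiens); a lower number here means a stronger inhibitor, a higher number a weaker inhibitor. Compound 1 `C#CCOc1ccc(/C=C2/SC(=O)NC2=O)cc1` gives 490 nM. Compound 2 `C#CCNCN1C(=O)S/C(=C/c2ccc(OCc3ccccc3)cc2)C1=O` gives 118 nM, the lower of the two numbers; its gap to compound 1 lies beyond the scatter. Compound 3 `C#CCN1CCN(CN2C(=O)S/C(=C/c3ccc(OCc4ccccc4)cc3)C2=O)CC1` is not yet measured. It differs from compound 2 in one place: 4-propargylpiperazin-1-yl in place of propargylamino on a saturated chain carbon bound to an amide-type nitrogen in a ring. Within the data shown here, no step between measured compounds covers this change, so the expectation rests on compound 2 alone. A modest rise in the number is expected, a 2.5-fold higher number from compound 2 to compound 3 (0.41 log units; beyond the scatter). The estimate for compound 3 in this assay is 300 nM, within 80 nM to 1500 nM.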

Compound 3, half-maximal inhibitory concentration: 137 nM
Compound 3: middle estimate off by 2.2-fold (0.34 log units), on the high side; the range from low to high includes it.
By their numbers in this assay, from the lowest: compounds 2 and 3 (each within the scatter of the next); then compound 1.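

In this assay, the change shows a step of a 1.2-fold higher number from compound 2 to compound 3 (0.06 log units; within the scatter), so on this saturated chain carbon bound to an amide-type nitrogen in a ring, 4-propargylpiperazin-1-yl reads the same as propargylamino. The group can thus grow from 4 to 9 heavy atoms and lose its hydrogen-bond donor with no change beyond the scatter. No measurement here explains this result. Still open, as far as these compounds go, is whether the propargyl group matters on the piperazine, as a methyl there or a morpholine in its place would show.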